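Aryl exchange at one place in a flat series

A few compounds are considered here, and "the series" means these few. Any claim that something is new, unique, unknown or untested is made for them only; others in the source may bear on it.

In a functional assay on SW-620 cells (Homo sapiens) for antiproliferative activity, read by MTT assay, with a stated time of 72 h (a lower number here means a stronger inhibitor, a higher number a weaker inhibitor), compound 2 (`COc1cc(/C=C2\CCC/C(=C\c3ccccc3Br)C2=O)cc(OC)c1OC`) gives 3300 nM, within the scatter of compound 1 (`COc1cc(/C=C2\CCC/C(=C\c3ccc(O)c(O)c3)C2=O)cc(OC)c1OC`) at 3200 nM and of compound 3 (`COc1cc(/C=C2\CCC/C(=C\c3ccccc3F)C2=O)cc(OC)c1OC`) at 2100 nM. Compound 4 (`COc1cc(/C=C2\CCC/C(=C\c3ccc(O)c(Cl)c3)C2=O)cc(OC)c1OC`) differs from compound 2 by 3-chloro-4-hydroxyphenyl in place of 2-bromophenyl on a double-bonded chain carbon bound to a double-bonded ring carbon, on a double-bonded chain carbon bound to a double-bonded ring carbon. The closest measured change at this place is a 1.0-fold higher number from compound 1 to compound 2 (0.01 log units; within the scatter), which also exchanges a hydroxy-bearing ring for the 2-bromophenyl group. The other two steps, a 1.5-fold lower number from compound 1 to compound 3 (0.18 log units; within the scatter) and a 1.6-fold lower number from compound 2 to compound 3 (0.20 log units; within the scatter), are equally small. No step beyond the scatter is therefore expected in this assay, and the expected change is a 1.3-fold lower number from compound 2 to compound 4 (0.12 log units; within the scatter). For compound 4 the estimated value is 2500 nM, with an expected range of 900 nM to 6500 nM.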

Compound 4, half-maximal inhibitory concentration: 800 nM
For compound 4 the middle estimate is 3.1-fold (0.49 log units) above the measured one; measured number outside the range, below it.
By their numbers in this assay, from the lowest: compound 4; then compounds 3, 1 and 2 (each within the scatter of the next).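

In this assay this position is no longer flat: a 4.1-fold lower number from compound 2 to compound 4 (0.62 log units; beyond the scatter) and a 2.6-fold lower number from compound 3 to compound 4 (0.42 log units; beyond the scatter), both beyond the scatter, unlike every earlier step. Chloro in place of hydroxy on an aromatic carbon alone gives a 4.0-fold lower number from compound 1 to compound 4 (0.60 log units; beyond the scatter), so compound 4 stands apart from all three earlier compounds through a single-atom exchange on the ring. No supporting evidence accounts for this step. Open, as far as these compounds go, is whether chloro holds this gain without the hydroxy group of 3-chloro-4-hydroxyphenyl. Also open, from the compounds shown here alone, is whether an amine or a carboxylic acid in place of that hydroxy group would keep it.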